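The source may report more compounds than this note shows. Statements on the series, on what has been measured and on what is new or still open speak of the compounds shown alone.

Compound 1 `CCCCN(c1nc2c(CO)cccc2o1)[C@H](C)c1ccc(-c2ccccc2-c2nnn[nH]2)cc1` carries a hydroxymethyl on its fused core, and in an ADME assay on the whole organism (Macaca fascicularis) for pharmacokinetics, read by LC-MS, using cassette dosing (on this read-out higher numbers stand for higher oral bioavailability and lower numbers for lower oral bioavailability), compound 1 gives 0.8%. That is the lowest of the three numbers on record. Compound 2 `Cc1ccc(-c2nc(=O)o[nH]2)c(-c2ccc([C@@H](C)N(CC3CC3)c3nc4c(C(=O)O)cccc4o3)cc2)c1` gives 58% in this assay, and compound 3 `C[C@H](c1ccc(-c2cc(F)ccc2-c2nc(=O)o[nH]2)cc1)N(CC1CC1)c1nc2c(C(=O)O)cccc2o1` gives 82%; both stand far beyond the scatter above compound 1. For the measured compounds named here, the single step between measured compounds, a number 24 percentage points higher from compound 2 to compound 3 (beyond the scatter), concerns a change on the outer aromatic ring and not on the fused core, so it does not speak to the change now in question.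

Compound 4 `CCCCN(c1nc2c(-c3nccn3C)cccc2o1)[C@H](C)c1ccc(-c2ccccc2-c2nnn[nH]2)cc1` differs from compound 1 in one place: 1-methyl-1H-imidazol-2-yl in place of hydroxymethyl on an aromatic carbon. Going by the values given here, no measured pair shows what a change at this position does to oral bioavailability, and the scaffold of compound 1 is otherwise unlike those of compound 2 and compound 3, which carry a carboxylic acid on the core instead. The expectation therefore rests on compound 1 alone, which gives 0.8%. A step of a number 5.2 percentage points higher from compound 1 to compound 4 (within the scatter) is expected from compound 1 to compound 4, upward but not far beyond the scatter. Compound 4 is estimated to give 6% in this assay, within a range from 0.5% to 30%.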

Compound 4, oral bioavailability: 7.5%
The estimate for compound 4 lay 1.5 percentage points below the measured number, within the range that was stated.
By their numbers in this assay, from the lowest: compounds 1 and 4 (each within the scatter of the next); then compound 2; then compound 3.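

In this assay, for the compounds shown here, the exchange of hydroxymethyl for 1-methyl-1H-imidazol-2-yl gives the first reading at this position, on an aromatic carbon of the six-membered aromatic ring of carbon only, and it comes out as a number 6.7 percentage points higher from compound 1 to compound 4 (within the scatter). The step shows that this single exchange, in which the hydrogen-bond donor of hydroxymethyl leaves and a five-membered aromatic ring with 2 hetero atoms enters, does not separate the two compounds on this read-out, so one change of this kind at this position does not by itself lift the core of compound 1 beyond the scatter. Nothing at hand bears on why the two compounds stay within the scatter of each other.

Still open, on these data alone, is whether a different group at this position, such as an aminomethyl or a primary carboxamide, would give a step beyond the scatter on the core of compound 1. Also open, as far as these compounds go, is what replacing the butyl chain of compound 1 with a cyclopropylmethyl group, as a single change, would do on this read-out.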